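Swapping methoxy for bromo on a second scaffold

The source may hold more compounds than are shown below. What is called first, only, known or untested is meant among the compounds shown, and "the series" means these compounds.

Compound 1 `COc1ccc(CN2C(=O)C(=O)c3cc(/C=C/C(=O)N4CCCC4)ccc32)cc1` and compound 2 `O=C1C(=O)N(Cc2ccc(Br)cc2)c2ccc(/C=C/C(=O)N3CCCC3)cc21` share one core and differ in only one spot: bromo in place of methoxy on an aromatic carbon. In a functional assay on Jurkat cells (Homo sapiens) for antiproliferative activity, read by MTT assay, with a stated time of 48 h (a higher number here means a weaker inhibitor, a lower number a stronger inhibitor), compound 1 gives 2240 nM, and compound 2 gives 3190 nM. The step of a 1.4-fold higher number from compound 1 to compound 2 (0.15 log units; within the scatter) is one that the measurement cannot tell apart from no change at all.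

Compound 3 `COC(=O)/C=C/c1ccc2c(c1)/C(=N/O)C(=O)N2Cc1ccc(OC)cc1` is built on a different core; how its core differs from that of compound 1 is not broken down here. In this assay compound 3 gives 9110 nM, the highest of the three numbers, separated from both compound 1 and compound 2 by more than the usual scatter.

Compound 4 `COC(=O)/C=C/c1ccc2c(c1)/C(=N/O)C(=O)N2Cc1ccc(Br)cc1` repeats on the core of compound 3 exactly the change already seen on the first core, (bromo in place of methoxy on an aromatic carbon), in the same place on the ring. Nothing else is altered. Among the measured compounds shown here, with only one earlier example of this change, the expectation rests on that single pair: because a 1.4-fold higher number from compound 1 to compound 2 (0.15 log units; within the scatter) stayed within the scatter, the same change is expected to move compound 4 only a little as well. The step is estimated as a 1.3-fold higher number from compound 3 to compound 4 (0.12 log units; within the scatter). Compound 4 is therefore expected to give about 12000 nM, most likely between 5000 nM and 30000 nM.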

Compound 4, half-maximal inhibitory concentration: 5860 nM
Compound 4: the middle estimate sits 2.0-fold (0.31 log units) above what was measured, within the range that was stated.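

On the core of compound 3, putting bromo in place of methoxy gives a 1.6-fold lower number from compound 3 to compound 4 (0.19 log units; within the scatter) in this assay, so on this core too the measurement cannot tell the change apart from no change at all. Although one step prints as a higher number and the other as a lower one, that opposite direction cannot be read as a real reversal, and the two cores give the same answer as far as the data can tell: the same change on two cores in this assay, a 1.4-fold higher number (0.15 log units; within the scatter) from compound 1 to compound 2 and a 1.6-fold lower number (0.19 log units; within the scatter) from compound 3 to compound 4, 2.2-fold (0.35 log units) apart, within the scatter of two such steps

What this shows is that, in these two pairs and in this one cell assay, 4-methoxybenzyl and 4-bromobenzyl could not be told apart; it does not show that the change would stay this small on any further core, and it says nothing about why the step is small.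

The compounds shown leave open whether a different group at this same place on the ring, such as an amine, a carboxylic acid or a longer chain, would move the number beyond the scatter. Among the compounds shown here, they also leave open what each difference between the two cores contributes, as no pair here changes just one of those differences at a time.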